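This account rests on a few compounds, and the source may have more. Where it says the series, first, only, none or still open, it means among the compounds named here.

Going by the values given here, in a functional assay on HepG2 cells (Homo sapiens) for antiproliferative activity, read by MTT assay, with a stated time of 72 h (on this read-out lower numbers stand for stronger inhibition and higher numbers for weaker inhibition), compound 2 (`COc1ncc(-c2ccc3c(c2)NC(=O)CO3)cc1NS(=O)(=O)c1ccc(F)cc1`) gives 6590 nM, the only true number so far. Compound 3 (`COc1cccc(N2C(=O)COc3ccc(-c4cnc(OC)c(NS(=O)(=O)c5ccc(F)cc5)c4)cc32)c1`) differs from compound 2 by 3-methoxyphenyl in place of hydrogen on an amide-type nitrogen in a ring, with 3-methoxyphenyl in place of hydrogen on an amide-type nitrogen in a ring. Compound 1 (`COc1cccc(N2C(=O)COc3ccc(-c4cnc(Cl)c(NS(=O)(=O)c5ccc(F)cc5)c4)cc32)c1`), which also carries 3-methoxyphenyl, gives > 40000 nM, a limit of the assay and not a number. Among the compounds with values here, no measured step isolates this change, so the forecast is uncertain. Somewhat weaker inhibition in this assay is expected, the estimate being a 2.3-fold higher number from compound 2 to compound 3 (0.36 log units; beyond the scatter). For compound 3 the expected value is 15000 nM, within an estimated range of 3000 nM to 40000 nM.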

Compound 3, half-maximal inhibitory concentration: > 40000 nM
Compound 3 was reported as a limit; the forecaster's own chance of this, stated with the estimate: 30%; middle value at least 2.6-fold (0.42 log units) from the limit.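

Putting 3-methoxyphenyl in place of hydrogen on the amide-type nitrogen in a ring weakens inhibition in this assay, giving an at least 6.0-fold higher number from compound 2 to compound 3 (0.78 log units; beyond the scatter), the first step measured at this position. Compound 3 stands at a limit of the assay, so this step gives only a lower bound on the change, and the same limit recurs across the series: the limit of > 40000 nM in this assay, at which 2 of the 3 values shown sit. The step between the two limits, methoxy in place of chloro, cannot be read.

Open, from the compounds shown here alone, is how a methyl group or a longer chain ending in an amine would fare on that nitrogen.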